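The source may report more compounds than this note shows. Statements on the series, on what has been measured and on what is new or still open speak of the compounds shown alone.

Measured so far in a functional assay on K562 cells (Homo sapiens) for antiproliferative activity, read by MTT assay; a lower number here means a stronger inhibitor, a higher number a weaker inhibitor

- compound 1 `O=C(CCCCCNC(=S)NN=C(c1ccccc1)c1ccccc1)NO` gives 3810 nM
- compound 2 `O=C(CCCCCNC(=S)N/N=C(\c1ccccc1)c1cccc([N+](=O)[O-])c1)NO` gives 1630 nM

Of these two, compound 2 has the lower number (1630 nM) and serves as the reference for the next change. Compound 3 `O=C(CCCCCNC(=S)N/N=C(\c1ccccc1)c1ccc([N+](=O)[O-])cc1)NO` has the same atoms joined differently (4-nitrophenyl in place of 3-nitrophenyl on a carbon with a double bond to nitrogen), with 4-nitrophenyl in place of 3-nitrophenyl on a carbon with a double bond to nitrogen.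

Among the measured compounds shown here, one measured step bears on this, and only in part. The modest 2.3-fold lower number from compound 1 to compound 2 (0.37 log units; beyond the scatter) comes with nitro in place of hydrogen on an aromatic carbon. For the measured compounds named here, no measured pair shows what the move from 3-nitrophenyl to 4-nitrophenyl does, so that step offers a rough scale and no direction. In this assay the change is therefore expected to stay within the scatter, with the number close to that of compound 2 (1630 nM). The expected step is small (a 1.1-fold lower number from compound 2 to compound 3 (0.04 log units; within the scatter)). Compound 3 is estimated at 1500 nM with an expected range (750 nM to 3200 nM).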

Compound 3, half-maximal inhibitory concentration: 2890 nM
Beside the measured number, compound 3's estimate is 1.9-fold (0.28 log units) below it, and the stated range covers the measured number.
By their numbers in this assay, from the lowest: compounds 2, 3 and 1 (each within the scatter of the next, the first and the last beyond it).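

In this assay, the shift from 3-nitrophenyl to 4-nitrophenyl on the carbon with a double bond to nitrogen gives a 1.8-fold higher number from compound 2 to compound 3 (0.25 log units; within the scatter) and so does not separate these two groups at this position. Set against the unsubstituted compound 1, the nitro group gives a 2.3-fold lower number from compound 1 to compound 2 (0.37 log units; beyond the scatter) as 3-nitrophenyl but a 1.3-fold lower number from compound 1 to compound 3 (0.12 log units; within the scatter) as 4-nitrophenyl, so only the 3-nitrophenyl compound stands clear of the scatter from compound 1, while compound 3 cannot be told apart from either neighbour. Nothing on hand accounts for these numbers.

Open, going by these compounds, is whether an amine or a carboxylic acid in place of the nitro group on the same phenyl ring would give a step beyond the scatter from compound 1, and in which direction. Also open is whether the small differences among these three compounds would hold with a longer chain between the thiourea-bearing nitrogen and the hydroxamic acid end of the shared core.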